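Pyrazoline sulfonamides: cytotoxicity in MT4 cells, halogen swap

The source may hold more compounds than are shown below. What is called first, only, known or untested is meant among the compounds shown, and "the series" means these compounds.

Measured compounds:
Compound 1, `NS(=O)(=O)c1ccc(N2N=C(c3ccc(Oc4ccccc4)cc3)CC2c2cccc(F)c2)cc1`, 25000 nM in an ADME assay on MT4 cells (Homo sapiens) for cytotoxicity, read by MTT assay, with a stated time of 96 h; on this read-out higher numbers stand for lower toxicity in this test and lower numbers for higher toxicity in this test.
Compound 2, `NS(=O)(=O)c1ccc(N2N=C(c3ccc(Oc4ccccc4)cc3)CC2c2cccc(Cl)c2)cc1`, 8000 nM.
Compound 3, `NS(=O)(=O)c1ccc(N2N=C(c3ccc(OCc4ccccc4)cc3)CC2c2cccc(Cl)c2)cc1`, 36000 nM.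

Compound 4, `NS(=O)(=O)c1ccc(N2N=C(c3ccc(OCc4ccccc4)cc3)CC2c2cccc(F)c2)cc1`, is not yet measured. Compound 3 and compound 4 differ by fluoro in place of chloro on an aromatic carbon. The same change, (fluoro in place of chloro on an aromatic carbon), separates compound 2 from compound 1, and there it gave a 3.1-fold higher number from compound 2 to compound 1 (0.49 log units; beyond the scatter). The cores of compound 2 and compound 3 differ by benzyl in place of phenyl on an oxygen on an aromatic ring, a change that gave a 4.5-fold higher number from compound 2 to compound 3 (0.65 log units; beyond the scatter).

Compound 3 already stands at the highest of the three numbers. For the measured compounds named here, because the earlier halogen swap gave a 3.1-fold higher number from compound 2 to compound 1 (0.49 log units; beyond the scatter), a step of about a 2.5-fold higher number from compound 3 to compound 4 (0.40 log units; beyond the scatter) is expected from compound 3 to compound 4 in this assay, with the reservation that only one such pair is known. Compound 4 is therefore estimated at 90000 nM, likely between 40000 nM and 200000 nM, and a reported limit rather than a number is plausible.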

Compound 4, half-maximal cytotoxic concentration: 65000 nM
Compound 4: the middle estimate sits 1.4-fold (0.14 log units) above what was measured; the range from low to high includes it.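

In this assay, 3-chlorophenyl to 3-fluorophenyl on the benzyl ether core gives a 1.8-fold higher number from compound 3 to compound 4 (0.26 log units; within the scatter), a step that alone cannot be told from scatter but agrees in size with the same change on the phenyl ether core: the same change on two cores in this assay, a 3.1-fold higher number (0.49 log units; beyond the scatter) from compound 2 to compound 1 and a 1.8-fold higher number (0.26 log units; within the scatter) from compound 3 to compound 4, 1.7-fold (0.24 log units) apart, within the scatter of two such steps

Benzyl in place of phenyl on the oxygen gives a 2.6-fold higher number from compound 1 to compound 4 (0.41 log units; beyond the scatter), and this change also carries over between the fluoro and chloro cores: the same change on two cores in this assay, a 4.5-fold higher number (0.65 log units; beyond the scatter) from compound 2 to compound 3 and a 2.6-fold higher number (0.41 log units; beyond the scatter) from compound 1 to compound 4, 1.7-fold (0.24 log units) apart, within the scatter of two such steps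

This shows the two changes carrying across this one square of four compounds, but it does not show that they would carry to any other core.

The compounds shown leave open how bromo or an amine on that aromatic carbon would read in this assay. Going by these compounds, whether a longer chain on the oxygen would extend the benzyl step also remains open.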